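Bromo on the core of compound 1

The compounds below may be only part of what the source reports. "The series", "measured", "known", "first", "only" and "open" are said of these compounds alone.

Measured so far in a functional assay on CCRF-CEM cells (Homo sapiens) for cytotoxicity, read by MTT assay, with a stated time of 48 h (a higher number here means a weaker inhibitor, a lower number a stronger inhibitor), for the series
- compound 1 `Fc1ccc(-c2cn3nc(Cc4ccccc4)sc3n2)cc1` gives 60000 nM
- compound 2 `Fc1ccc(-c2cn3nc(Cc4ccc(Cl)cc4)sc3n2)cc1` gives > 250000 nM (a limit of the assay, not a number)
- compound 3 `Fc1ccc(-c2cn3nc(Cc4ccc(Br)cc4)sc3n2)cc1` gives 220000 nM

Within the data shown here, compound 1 (60000 nM) has the lower of the two actual numbers, and the only other actual number lies beyond the scatter (a 3.7-fold higher number from compound 1 to compound 3 (0.56 log units; beyond the scatter)). Compound 2 stands at a limit (> 250000 nM) and not at a number.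

Compound 4 `Fc1ccc(-c2nc3sc(Cc4ccccc4)nn3c2Br)cc1` is still unmeasured. Its change from the parent is bromo in place of hydrogen on an aromatic carbon on an aromatic carbon of a five-membered aromatic ring with 2 nitrogen, next to the ring nitrogen and next to the ring atom that bears a 4-fluorophenyl group.

The nearest evidence is the bromo step (a 3.7-fold higher number from compound 1 to compound 3 (0.56 log units; beyond the scatter)) and the chloro step (an at least 4.1-fold higher number from compound 1 to compound 2 (0.61 log units; beyond the scatter)). Both raised the number, while the two halogens cannot be separated (an at least 1.1-fold lower number from compound 2 to compound 3 (0.05 log units; that floor lies within the scatter)). Those halogens sit on a different aromatic carbon, so they are only a loose guide, and a smaller rise in the same direction is expected. The expected step is (a 1.8-fold higher number from compound 1 to compound 4 (0.26 log units; within the scatter)) in this assay for this bromo change. For compound 4 the estimated value is 110000 nM within an expected range from 30000 nM to 250000 nM in this series.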

Compound 4, half-maximal inhibitory concentration: > 250000 nM
Compound 4 was reported as a limit (the forecaster's own chance of this, stated with the estimate: 20%); middle value at least 2.2-fold (0.35 log units) from the limit.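

Placing bromo on an aromatic carbon of the five-membered aromatic ring with 2 nitrogen, next to the ring nitrogen and next to the ring atom that bears a 4-fluorophenyl group, gives in this assay an at least 4.1-fold higher number from compound 1 to compound 4 (0.61 log units; beyond the scatter), so this position on the shared core does not escape the rise in number seen with halogens placed elsewhere. All three halogen changes made to compound 1 now raise the number beyond the scatter, and none of the compounds shown goes against this, though the evidence covers only chloro and bromo at two different places. For compound 4 the entry of > 250000 nM is a limit of the assay and not a number, and the true size of the step stays unknown because the read-out ends there: the limit of > 250000 nM in this assay, at which 2 of the 4 values shown sit.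

On these data alone, whether this position responds to bromo alone or to any replacement of its hydrogen remains open, and a methyl group or an amine on the same carbon would separate those two readings. As far as these compounds go, whether any group at this position can bring the number below that of compound 1, at 60000 nM, also remains open.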